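The source may report more compounds than this note shows. Statements on the series, on what has been measured and on what is new or still open speak of the compounds shown alone.

In a functional assay on MGC-803 cells (Homo sapiens) for antiproliferative activity, read by MTT assay, with a stated time of 72 h (on this read-out lower numbers stand for stronger inhibition and higher numbers for weaker inhibition), three compounds of one shared core have been measured. Compound 1 `CCCSc1nc(N/N=C/c2cccnc2)c2nnn(Cc3ccccc3)c2n1` gives 38100 nM, compound 2 `C#CCSc1nc(N/N=C(\C)c2ccccc2O)c2nnn(Cc3ccccc3)c2n1` gives 3820 nM, and compound 3 `C#CCSc1nc(N/N=C/c2ccc(N(C)C)cc2)c2nnn(Cc3ccccc3)c2n1` gives 7620 nM. Compound 2 shows the lowest of these numbers, yet compound 3 lies within the usual scatter of it, while compound 1 lies well beyond. Compound 4 `C/C(=N\Nc1nc(SCc2ccccc2)nc2c1nnn2Cc1ccccc1)c1ccccc1O` has not been measured; it differs from compound 2 only at the sulfur-bound chain: phenyl in place of ethynyl on a saturated chain carbon bound to a sulfur. Among the compounds with values here, no measured pair isolates such a change, so the step is an expectation only. The step of a 1.0-fold higher number from compound 2 to compound 4 (0.02 log units; within the scatter) is expected to be small, in no firm direction, and within the scatter. Compound 4 is therefore estimated at 4000 nM, with a range from 1300 nM to 12000 nM.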

Compound 4, half-maximal inhibitory concentration: 850 nM
For compound 4 the middle estimate is 4.7-fold (0.67 log units) above the measured one; measured number outside the range, below it.
By their numbers in this assay, from the lowest: compound 4; then compounds 2 and 3 (each within the scatter of the next); then compound 1.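

In this assay, the sulfur-bound chain proves able to shift the read-out: changing propargyl to benzyl gives a 4.5-fold lower number from compound 2 to compound 4 (0.65 log units; beyond the scatter), the first single-place step seen in this set. On a saturated chain carbon bound to a sulfur, then, phenyl can take the place of ethynyl with a gain in inhibition. Nothing measured here explains this step.

Going by these compounds, this is one pair, so whether the phenyl ring itself matters remains open; a cyclohexyl ring, a pyridine ring or a longer chain such as phenethyl would test that. Whether the step carries over to the other side chain of compound 3 is also unknown.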